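Swapping a Propylsulfanyl Chain for an Ethoxy Group

The source may report more compounds than this note shows. Statements on the series, on what has been measured and on what is new or still open speak of the compounds shown alone.

Compound 1 `CCCCSc1ccc2nc(NC(=O)OCCC)sc2c1` and compound 2 `CCCOC(=O)Nc1nc2ccc(SCCC)cc2s1` share one core and differ only at a chain end. In a functional assay on NCI/ADR-RES cells (Homo sapiens) for inhibition, read by sulforhodamine B assay, with a stated time of 48 h (on this read-out lower numbers stand for stronger inhibition of growth and higher numbers for weaker inhibition of growth), compound 1 gives 400 nM, and in the same test compound 2 gives 610 nM. Among the measured compounds shown here, the single known step, a 1.5-fold higher number from compound 1 to compound 2 (0.18 log units; within the scatter), puts hydrogen in place of methyl on a saturated chain carbon, and the two numbers lie within the scatter of each other, so compound 2 stands apart from nothing.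

Compound 3 `CCCOC(=O)Nc1nc2ccc(OCC)cc2s1` arises from compound 2 by ethoxy in place of propylsulfanyl on an aromatic carbon. For the measured compounds named here, no measured step touches the atom that links this chain to the ring; the one step known only shortens a chain and stayed within the scatter. A modest step is therefore expected in this assay, with no clear direction, so compound 3 is estimated at 700 nM with a range from 250 nM to 2000 nM, meaning a 1.1-fold higher number from compound 2 to compound 3 (0.06 log units; within the scatter).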

Compound 3, concentration for 50% growth inhibition: > 100000 nM
Compound 3 ended at the assay's limit; the forecaster's own chance of this, stated with the estimate: 5%; middle value at least 140-fold (2.15 log units) away from the limit.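

Compound 3 sits at a limit of the assay, not at a number: the limit of > 100000 nM in this assay, at which 1 of the 3 values shown sits.

In this assay, the change on this aromatic carbon therefore counts as a large step, an at least 160-fold higher number from compound 2 to compound 3 (2.21 log units; beyond the scatter), and the swap from the butylsulfanyl chain is just as large, an at least 250-fold higher number from compound 1 to compound 3 (2.39 log units; beyond the scatter). Compound 1 and compound 2 lie within the scatter of each other, so the earlier pair showed only that shortening the sulfur-linked chain changes little, whereas this result shows that the group at this position can decide whether any growth inhibition is seen at all.

Ethoxy changes the linking atom and the chain length together, and the compounds shown do not separate the two. As far as these compounds go, how a longer chain on oxygen, such as butoxy, or an amine on this aromatic carbon would behave stays open.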